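Benzyl substituent swap in a cytotoxicity series

The source may report more compounds than this note shows. Statements on the series, on what has been measured and on what is new or still open speak of the compounds shown alone.

compound 1 `COC(=O)c1ccc(NCc2cncn2Cc2ccccc2N)cc1-c1ccccc1` — 25000 nM
compound 2 `CC(C)OC(=O)c1ccc(NCc2cncn2Cc2ccc(-c3ccccc3)cc2)cc1-c1ccccc1` — > 10000 nM (a limit)
compound 3 `c1ccc(-c2ccc(Cn3cncc3CNc3ccc(-c4nc5ccccc5o4)c(-c4ccccc4)c3)cc2)cc1` — > 10000 nM (a limit)

Among the measured compounds shown here, in a toxicity assay on NIH3T3 cells (Mus musculus) for cytotoxicity, read by resazurin assay (a higher number here means that more compound is needed for the effect, a lower number that less compound is needed), compound 1 gives 25000 nM, the only plain number among the three. Compound 2 reaches only a limit, > 10000 nM. Compound 3 likewise stops at a limit, > 10000 nM. For the measured compounds named here, the sole step between measured compounds, a step that the two limits leave unreadable from compound 2 to compound 3, is therefore unreadable, as the limit of > 10000 nM in this assay, at which 2 of the 3 values shown sit, shows. Compound 4 `COC(=O)c1ccc(NCc2cncn2Cc2cccc(C(C)(C)C)c2)cc1-c1ccccc1` differs from compound 1 by 3-(tert-butyl)phenyl in place of 2-aminophenyl on a saturated chain carbon bound to an aromatic nitrogen. Going by the values given here, no measured step bears on this change; the one unreadable step concerns a different part of the molecule. With nothing pointing either way, no shift beyond the scatter is expected: compound 4 is estimated at 22000 nM (8000 nM to 60000 nM), an expected step of a 1.1-fold lower number from compound 1 to compound 4 (0.06 log units; within the scatter).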

Compound 4, half-maximal effective concentration: > 1000 nM
Compound 4 was reported as a limit; the forecaster's own chance of this, stated with the estimate: 40%; the middle value is on the limit's open side.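

Among the compounds shown here, compound 4 is reported only as a limit of > 1000 nM and no step from compound 1 to it can be read. As far as these compounds go, whether 3-(tert-butyl)phenyl in place of 2-aminophenyl shifts the read-out at all, and in which direction, stays open.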